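From Methylamino to Cyano on a Shared Core

This account rests on a few compounds, and the source may have more. Where it says the series, first, only, none or still open, it means among the compounds named here.

Compound 1 `COc1ccc(-c2c3c(nn2C(C)C)CCNCC3)cc1`: 18 nM
Compound 2 `CNc1ccc(-c2c3c(nn2C(C)C)CCNCC3)cc1`: 40 nM

In an assay on HEK293 cells for displacement of a labelled ligand from 5-hydroxytryptamine receptor 7 (Rattus norvegicus), read by radioligand binding (a higher number here means a weaker inhibitor, a lower number a stronger inhibitor), compound 2 gives 40 nM, the higher of the two numbers measured; its nearest neighbour, compound 1, gives 18 nM. Compound 3 `CC(C)n1nc2c(c1-c1ccc(C#N)cc1)CCNCC2` differs from compound 2 by cyano in place of methylamino on an aromatic carbon. Within the data shown here, no measured step covers this change. Among the measured compounds shown here, the only step known, a 2.2-fold higher number from compound 1 to compound 2 (0.35 log units; beyond the scatter), shows that exchanging the group on that aromatic carbon shifted this assay by a modest amount. A modest step of uncertain direction is therefore expected for compound 3, a 1.1-fold higher number from compound 2 to compound 3 (0.05 log units; within the scatter). The estimate for compound 3 is 45 nM, within a range of 12 nM to 160 nM.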

Compound 3, inhibition constant: 90 nM
Estimate against measurement, compound 3: 2.0-fold (0.30 log units) below, within the range that was stated.
By their numbers in this assay, from the lowest: compound 1; then compound 2; then compound 3.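

On this aromatic carbon, cyano in place of methylamino gives a 2.3-fold higher number from compound 2 to compound 3 (0.35 log units; beyond the scatter) in this assay, and cyano in place of methoxy gives a 5.0-fold higher number from compound 1 to compound 3 (0.70 log units; beyond the scatter) in the same test. Both steps lie beyond the scatter, so the three groups now stand in a clear order, from the lowest number to the highest: methoxy, methylamino, cyano. Nothing measured here explains that order.

Going by these compounds, whether a plain amine, a carboxylic acid or a chlorine atom at this place would fit within that order or fall outside it remains open.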